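Notes on compound 3: fluoro in place of trifluoromethyl

This account rests on a few compounds, and the source may have more. Where it says the series, first, only, none or still open, it means among the compounds named here.

Measured so far:
compound 1 `CC#CC(CC(=O)O)c1ccc(OCc2ccc3nc(-c4ccc(C(F)(F)F)cc4)cn3c2)cc1`: 558 nM
compound 2 `CC#CC(CC(=O)O)c1ccc(OCc2ccn3cc(-c4ccccc4C)nc3c2)cc1`: 459 nM

Both compounds were measured in an assay on isolated protein for agonist activity at Free fatty acid receptor 1 (Homo sapiens); on this read-out higher numbers stand for an effect only at larger amounts of compound and lower numbers for an effect already at smaller amounts. Compound 1 gives 558 nM, and compound 2 gives 459 nM. Among the measured compounds shown here, of the two numbers the one for compound 1 is the higher, but the gap to compound 2 lies within the scatter, so the two compounds cannot be told apart on this read-out. For the measured compounds named here, the two compounds also differ in more than one place, so no single step can be drawn between them.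

Compound 3 `CC#CC(CC(=O)O)c1ccc(OCc2ccc3nc(-c4ccc(F)cc4)cn3c2)cc1` has not been measured. It differs from compound 1 in one place: fluoro in place of trifluoromethyl on an aromatic carbon. Going by the values given here, no step between measured compounds bears on this change, so the expectation rests on the shared core and on compound 1 alone. The change is expected to bring at most a small weakening, close to the scatter. The expected value for compound 3 in this assay is 750 nM, with a range from 300 nM to 2000 nM. This estimate means an expected step of a 1.3-fold higher number from compound 1 to compound 3 (0.13 log units; within the scatter).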

Compound 3, half-maximal effective concentration: 623 nM
Beside the measured number, compound 3's estimate is 1.2-fold (0.08 log units) above it; the measured number falls inside the stated range.
By their numbers in this assay, from the lowest: compounds 2, 1 and 3 (each within the scatter of the next).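

In this assay, among the compounds shown here, the change from 4-(trifluoromethyl)phenyl to 4-fluorophenyl gives the first step that differs in one place only, a 1.1-fold higher number from compound 1 to compound 3 (0.05 log units; within the scatter). On this read-out, the two groups cannot be told apart at this place on the aromatic ring, even though trifluoromethyl has 4 heavy atoms and fluoro has 1, so the full trifluoromethyl group is not required to stay within the scatter of compound 1. No data on the properties of these two groups bear on this result, so it remains an observation without an explanation.

Going by these compounds, both groups have 0 hydrogen-bond donors, 0 hydrogen-bond acceptors and no net charge, so it remains open whether this place would accept a group of a different kind, such as an amine or a carboxylic acid, or whether plain hydrogen would also stay within the scatter. Compound 2 differs from compound 1 in more than one place, so it cannot show whether the same result would hold on its core or with its methyl-substituted phenyl group.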